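This account rests on a few compounds, and the source may have more. Where it says the series, first, only, none or still open, it means among the compounds named here.

Compound 1, `CCc1ccc(-c2ccc(C(=O)Nc3ccc(Oc4ccnc5[nH]ccc45)cc3)nc2)cc1`, was tested in a functional assay on PC-3 cells (Homo sapiens) for cytotoxicity, read by MTT assay, with a stated time of 72 h (a lower number here means a stronger inhibitor, a higher number a weaker inhibitor), and there compound 1 gives > 10000 nM, which is a limit of the assay rather than a number. Among the measured compounds shown here, compound 2, `COc1ccc(-c2ccnc(C(=O)Nc3ccc(Oc4ccnc5[nH]ccc45)cc3)c2)cc1`, is the only compound of the two for which a number is known: in this assay compound 2 gives 9620 nM. It therefore stands alone on the numbers shown, with the other value sitting at the limit of > 10000 nM in this assay, at which 1 of the 2 values shown sits.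

The step under consideration leads from compound 2 to compound 3, `O=C(Nc1ccc(Oc2ccnc3[nH]ccc23)cc1)c1cc(-c2ccccc2)ccn1`. The change is hydrogen in place of methoxy on an aromatic carbon, so that the 4-methoxyphenyl of compound 2 becomes a plain phenyl in compound 3. For the measured compounds named here, no measured pair in this set traces a comparable change, so no step can be quoted for it.

On that basis the expectation is a small step, if any: compound 3 is expected to sit close to compound 2, with a shift of about a 1.1-fold higher number from compound 2 to compound 3 (0.06 log units; within the scatter) in this assay lying within the usual scatter of repeated measurements. Compound 3 is accordingly estimated at 11000 nM, in a range from 4000 nM to 30000 nM, with a real chance that the assay reports only a limit.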

Compound 3, half-maximal inhibitory concentration: 3270 nM
For compound 3 the middle estimate is 3.4-fold (0.53 log units) above the measured one, outside the stated range (below it).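

In this assay, among the compounds shown here, the change from 4-methoxyphenyl to phenyl gives a 2.9-fold lower number from compound 2 to compound 3 (0.47 log units; beyond the scatter), the first step in this set that can be read and one that lies beyond the scatter. It shows that this place, on an aromatic carbon para to a large group, is not indifferent to what stands there, and that the methoxy is not required for the activity seen here, since the plain phenyl of compound 3 gives the lower number. Nothing given here accounts for the size or direction of this step.

Going by these compounds, only hydrogen and methoxy have been compared at this place, so it remains open whether a fluorine, an amine or a longer chain such as ethoxy would lower the number further or raise it again, and whether the step would hold in any other setting. Compound 1 differs from compound 3 in more than one place and its value is only a limit of the assay, so it adds no further step: the limit of > 10000 nM in this assay, at which 1 of the 3 values shown sits.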